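The source may hold more compounds than are shown below. What is called first, only, known or untested is meant among the compounds shown, and "the series" means these compounds.

The study compares three close relatives that share one core and differ only in the aryl group carried on the amine nitrogen. Compound 1 `O=C1C(Nc2ccccc2)=CC(=O)c2c1nc1n2[C@H]2OC[C@@H](O)[C@H]2OC1` carries a plain phenyl there. In a functional assay on HeLa cells (Homo sapiens) for inhibition, read by sulforhodamine B assay (on this read-out higher numbers stand for weaker inhibition and lower numbers for stronger inhibition), compound 1 gives > 8000 nM, which is a limit of the assay and not a number. Compound 2 `O=C1C=C(Nc2ccccc2F)C(=O)c2c1nc1n2[C@H]2OC[C@@H](O)[C@H]2OC1` carries a 2-fluorophenyl instead. In this assay compound 2 gives 5120 nM. Among the results shown, compound 2 stands as the only one with an actual number; the other result is a limit, recorded in the summary (the limit of > 8000 nM in this assay, at which 1 of the 2 values shown sits). Compound 3 `Cc1ccc(NC2=CC(=O)c3nc4n(c3C2=O)[C@H]2OC[C@@H](O)[C@H]2OC4)cc1C` is the next member and has not yet been measured. It differs from compound 2 in one place (3,4-dimethylphenyl in place of 2-fluorophenyl on an amine nitrogen). Among the compounds with values here, no step between two measured compounds is available to guide the expectation, because compound 1 gives > 8000 nM as a limit rather than a number. The step from compound 2 to compound 3 in this assay is therefore expected to be small, within the usual scatter and with no clear direction, as a 1.1-fold lower number from compound 2 to compound 3 (0.06 log units; within the scatter). Compound 3 is accordingly estimated at 4500 nM, with a range from 1500 nM to 12000 nM.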

Compound 3, half-maximal inhibitory concentration: 2690 nM
Beside the measured number, compound 3's estimate is 1.7-fold (0.22 log units) above it, within the range that was stated.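

Within the data shown here, with compound 3 the series gains a second actual number, and with it the first step that can be read at this place, on the amine nitrogen: a 1.9-fold lower number from compound 2 to compound 3 (0.28 log units; within the scatter). In this assay, then, exchanging 2-fluorophenyl for 3,4-dimethylphenyl, which removes the fluorine and brings in the dimethyl pattern on the same six-membered aromatic ring, does not separate the two compounds, so these two aryl groups cannot be ranked and the step gives no direction for this position. Among these compounds, compound 1 remains a limit of the assay and not a number, and no step involving it can be read: the limit of > 8000 nM in this assay, at which 1 of the 3 values shown sits.

The compounds shown leave open whether the number at this nitrogen can be moved beyond the scatter at all, for instance by a phenyl ring bearing a carboxylic acid or an amine, by a saturated ring such as cyclohexyl, or by a longer chain in place of the aryl group. Among the compounds shown here, they also leave open how fluorine and methyl substituents each act alone, since the single step readable here exchanges one substitution pattern for another.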